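A few compounds are considered here, and "the series" means these few. Any claim that something is new, unique, unknown or untested is made for them only; others in the source may bear on it.

Values in a functional assay on NUGC-3 cells (Homo sapiens) for inhibition, read by sulforhodamine B assay, with a stated time of 48 h; on this read-out lower numbers stand for stronger inhibition of growth and higher numbers for weaker inhibition of growth:

compound 1 `O=C(Nc1cccc(C(F)(F)F)c1)c1nccc2ccccc12` — > 10000 nM
compound 2 `O=C(Nc1ccc(Cl)cc1)c1nccc2ccccc12` — > 10000 nM
compound 3 `O=C(Nc1ccc(C(F)(F)F)cc1)c1nccc2ccccc12` — > 10000 nM

Compound 1 returns only a limit of this assay, not a number. Compound 2 likewise returns only a limit. Compound 3 too returns only a limit. All three sit at the limit of > 10000 nM in this assay, at which 3 of the 3 values shown sit, so no ordering among them can be read.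

Compound 3 and compound 2 differ by chloro in place of trifluoromethyl on an aromatic carbon; the step that the two limits leave unreadable from compound 3 to compound 2 cannot be sized, since both ends are limits. Compound 1 and compound 3 have the same atoms joined differently; the difference between these two cores is not broken down here.

Compound 4 `O=C(Nc1cccc(Cl)c1)c1nccc2ccccc12` is not yet measured. It differs from compound 1 by chloro in place of trifluoromethyl on an aromatic carbon. This is the same kind of change as from compound 3 to compound 2, but the place differs: meta to a large group in compound 4, para to a large group in compound 2.

Among the compounds with values here, with the only measured instance of this change unreadable, the expected step that the limit leaves unreadable from compound 1 to compound 4 rests on the limit of > 10000 nM in this assay, at which 3 of the 3 values shown sit, and on the unreadable a step that the two limits leave unreadable from compound 3 to compound 2; a further limit is the most likely outcome. Compound 4 is estimated at 20000 nM, between 7000 nM and 60000 nM.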

Compound 4, concentration for 50% growth inhibition: > 10000 nM
Compound 4 gave a limit, no number; the forecaster's own chance of this, stated with the estimate: 80%; the middle value does not contradict the limit.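

Compound 1 and compound 4 both return only limits, so no new step can be read between them and chloro in place of trifluoromethyl stays unsized: the limit of > 10000 nM in this assay, at which 4 of the 4 values shown sit.

The compounds shown leave open whether any change on the shared core brings growth inhibition to a readable number, and how chloro and trifluoromethyl compare.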